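This account rests on a few compounds, and the source may have more. Where it says the series, first, only, none or still open, it means among the compounds named here.

Working notes on the series. Of the compounds shown here, three with a shared core have been measured in a functional assay on CHO cells for antagonist activity at growth hormone secretagogue receptor type 1 (Homo sapiens); a higher number here means a weaker inhibitor, a lower number a stronger inhibitor: compound 1 `COc1ccc(Cn2c(CCc3ccccc3)nnc2[C@H](NC(=O)C(C)(C)N)c2c[nH]c3ccccc23)cc1`, compound 2 `COc1ccc(Cn2c(CCc3ccccc3)nnc2[C@H](NC(=O)c2ccccn2)c2c[nH]c3ccccc23)c(OC)c1` and compound 3 `COc1ccc(Cn2c(CCc3c[nH]c4ccccc34)nnc2[C@H](NC(=O)c2ccccn2)c2c[nH]c3ccccc23)cc1`. Compound 1 gives 5 nM, compound 2 gives 25 nM and compound 3 gives 102 nM. Compound 3 thus stands with the highest number of the three; its nearest neighbour is compound 2, and the gap to it is beyond the scatter, while the gap to compound 1 is wider still. Compound 2 and compound 3 differ in more than one place, so nothing beyond the two values themselves is read from that pair.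

Compound 4 `COc1ccc(Cn2c(CCc3ccccc3)nnc2[C@H](NC(=O)c2ccccn2)c2c[nH]c3ccccc23)cc1` is the next step from compound 3: phenyl in place of 1H-indol-3-yl on a saturated chain carbon, two bonds along the chain from an aromatic carbon. Compound 4 thereby carries the phenethyl chain that compound 1 and compound 2 also carry, and it matches compound 2 in every respect except the count of methoxy groups. Compound 2 gives 25 nM in this assay, which is the closest available reference for compound 4. The expected step of a 5.1-fold lower number from compound 3 to compound 4 (0.71 log units; beyond the scatter) is therefore toward a lower number, beyond the scatter. Compound 4 is expected at 20 nM, with a range from 6 nM to 70 nM.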

Compound 4, antagonist equilibrium constant: 12 nM
Beside the measured number, compound 4's estimate is 1.7-fold (0.22 log units) above it; measured number inside the range.
By their numbers in this assay, from the lowest: compound 1; then compound 4; then compound 2; then compound 3.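

In this assay, among the compounds shown here, the change from 2-(1H-indol-3-yl)ethyl to phenethyl gives an 8.5-fold lower number from compound 3 to compound 4 (0.93 log units; beyond the scatter) and is the first reading at this chain position in which nothing else differs, so the 1H-indol-3-yl group is not required for a low number with the pyridin-2-yl amide. For the compounds shown here, compound 4 also links the earlier compounds through single changes: hydrogen in place of methoxy on an aromatic carbon gives a 2.1-fold lower number from compound 2 to compound 4 (0.32 log units; beyond the scatter), while pyridin-2-yl in place of 1-amino-1-methylethyl on a carbonyl carbon gives a 2.4-fold higher number from compound 1 to compound 4 (0.38 log units; beyond the scatter), each step beyond the scatter and modest in size. The compounds shown offer no measurement that explains any of these three steps.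

Going by these compounds, only phenyl and 1H-indol-3-yl are compared at this chain position, so it remains open how a shorter benzyl chain, a longer 3-phenylpropyl chain or a naphthalen-2-yl group would read there. On these data alone, it is also open whether the phenyl-for-1H-indol-3-yl step carries over when 1-amino-1-methylethyl stands on the carbonyl carbon in place of pyridin-2-yl.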